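A few compounds are considered here, and "the series" means these few. Any claim that something is new, unique, unknown or untested is made for them only; others in the source may bear on it.

Compound 1 `COc1cc(/C=C/C(=O)c2cccc(NC(=O)c3ccc(Cl)cc3)c2)ccc1O` – 0.59 ug/mL
Compound 2 `COc1cc(/C=C/C(=O)c2cccc(NC(=O)c3ccco3)c2)ccc1O` – 5.46 ug/mL
Compound 3 `COc1cc(/C=C/C(=O)c2cccc(N)c2)ccc1O` – 11.5 ug/mL

All three values come from a functional assay on B16 cells (Mus musculus) for inhibition; a lower number here means a stronger inhibitor, a higher number a weaker inhibitor. Compound 3 has the highest number of the three, which makes it the weakest inhibitor in this small set. Compound 4 `COc1cc(/C=C/C(=O)c2cccc(NC(=O)c3ccc(Cl)cc3Cl)c2)ccc1O` differs from it by one change: (2,4-dichlorophenyl)carbonyl in place of hydrogen on a nitrogen on an aromatic ring. In words, (2,4-dichlorophenyl)carbonyl stands in place of hydrogen on a nitrogen on an aromatic ring.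

The closest evidence is a 19-fold higher number from compound 1 to compound 3 (1.29 log units; beyond the scatter), a large step in which hydrogen replaces (4-chlorophenyl)carbonyl. Read in reverse, it favours a much lower number for the acylated compound. The modest 2.1-fold higher number from compound 2 to compound 3 (0.32 log units; beyond the scatter) points the same way, while a 9.3-fold higher number from compound 1 to compound 2 (0.97 log units; beyond the scatter) shows that the outcome depends on the group carried by the carbonyl carbon. For the measured compounds named here, a large step towards a lower number is therefore expected, similar in size to the one involving compound 1.

The expected change is a 14-fold lower number from compound 3 to compound 4 (1.16 log units; beyond the scatter). For compound 4 the estimated value is 0.8 ug/mL, with an expected range of 0.25 ug/mL to 2.5 ug/mL.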

Compound 4, half-maximal inhibitory concentration: 12.8 ug/mL
The estimate for compound 4 lay 16-fold (1.20 log units) below the measured number; measured number above the stated range.
By their numbers in this assay, from the lowest: compound 1; then compound 2; then compounds 3 and 4 (each within the scatter of the next).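

In this assay, a carbonyl group on this nitrogen does not by itself bring a lower number: with (2,4-dichlorophenyl)carbonyl in place of hydrogen there is a 1.1-fold higher number from compound 3 to compound 4 (0.05 log units; within the scatter), so compound 4 goes against the trend set by compound 1 and compound 2. One further chloro in place of hydrogen on an aromatic carbon is enough to remove the whole advantage of compound 1, with a 22-fold higher number from compound 1 to compound 4 (1.34 log units; beyond the scatter), and 2,4-dichlorophenyl in place of furan-2-yl on the carbonyl carbon gives a 2.3-fold higher number from compound 2 to compound 4 (0.37 log units; beyond the scatter). Nothing available explains this loss.

From the compounds shown here alone, it remains open whether the loss is specific to chloro, or whether a methyl or methoxy group in place of that same hydrogen would give a similar number. Going by these compounds, how an amine or a carboxylic acid on this phenyl ring would read in this assay also remains open.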